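This account rests on a few compounds, and the source may have more. Where it says the series, first, only, none or still open, it means among the compounds named here.

Compound 1 `O=C(O)CCc1ccc(OCc2cccc(Br)c2)cc1` gives, in a functional assay on 1321-N1 cells for agonist activity at Free fatty acid receptor 1 (Homo sapiens), read by calcium flux (on this read-out higher numbers stand for larger maximal responses and lower numbers for smaller maximal responses), 99%.
Compound 2 `O=C(O)CCc1ccc(NCc2cccc(C(F)(F)F)c2)cc1` gives in this assay 102%.
Compound 3 `O=C(O)CCc1ccc(NCc2cccc(-c3ccccc3)c2)cc1` gives in this assay 101%.

The three measured values sit together: the number for compound 1 lies within the usual scatter of the number for compound 3 and also within the scatter of the number for compound 2, so no order among the three can be read from them, and all three reach essentially the full response of the reference.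

Compound 4 `Cc1ccc(-c2cccc(COc3ccc(CCC(=O)O)cc3)c2)cc1` differs from compound 1 in one place: 4-methylphenyl in place of bromo on an aromatic carbon. Among the measured compounds shown here, one measured step bears on this kind of change, the replacement of a small substituent by an aromatic ring on the same kind of position of the shared core: a number 1 percentage points lower from compound 2 to compound 3 (within the scatter). That step lies within the scatter, and compound 1 already stands at the level of the reference. Nothing in the data therefore points to a movement beyond the scatter in either direction.

On this basis compound 4 is expected to give about 100% in this assay, with a range from 85% to 112%. The step this estimate means is a number 1 percentage points higher from compound 1 to compound 4 (within the scatter), expected to fall within the scatter.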

Compound 4, largest response reached (reported as efficacy), in percent of the reference or control that the assay uses: 86%
The estimate for compound 4 lay 14 percentage points above the measured number; the range from low to high includes it.
By their numbers in this assay, from the lowest: compound 4; then compounds 1, 3 and 2 (each within the scatter of the next).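

In this assay, putting 4-methylphenyl in place of bromo on an aromatic carbon, meta to a large group, is the first change among these compounds to move the maximal response beyond the scatter: a number 13 percentage points lower from compound 1 to compound 4 (beyond the scatter). The earlier step, in which phenyl replaced trifluoromethyl on a related core, gave a number 1 percentage points lower from compound 2 to compound 3 (within the scatter), so an aromatic ring entering at this kind of place does not leave the response unchanged in every case, and the full response seen so far is not a fixed feature of the series. Nothing given here explains the lower number for compound 4.

The compounds shown cannot separate the contribution of the added ring from that of its methyl group, since none of them carries a plain phenyl at this place on the core of compound 1. From the compounds shown here alone, it also remains open whether the link in the core affects the outcome, a question that the 4-methylphenyl group on the core of compound 2, with its amine link, would address.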